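From compound 3 to a pyrimidin-5-yl amine

The compounds below may be only part of what the source reports. "The series", "measured", "known", "first", "only" and "open" are said of these compounds alone.

These notes cover four compounds that share a core and differ in the group it carries. Going by the values given here, in a functional assay on CWR22R cells (Homo sapiens) for antiproliferative activity, read by CCK-8 assay, with a stated time of 6 days (on this read-out lower numbers stand for stronger inhibition and higher numbers for weaker inhibition), compound 1 `CC(O)c1cccc(C(=O)N[C@@H](C)Cn2ccc(-c3ccc(C#N)c(Cl)c3)n2)c1` gives 20100 nM and this is the only number so far. Compound 2 `CC(=O)c1ccc(C(=O)N[C@@H](C)Cn2ccc(-c3ccc(C#N)c(Cl)c3)n2)cc1` has the entry "not determined" (no result reported) with no result reported. Compound 3 `COC(=O)/C=C/C(=O)N[C@@H](C)Cn1ccc(-c2ccc(C#N)c(Cl)c2)n1` has the entry "not determined" (no result reported) as well, so it holds no place on the scale of this assay and cannot be ranked against compound 1.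

The compound next in line is compound 4 `C[C@@H](Cn1ccc(-c2ccc(C#N)c(Cl)c2)n1)Nc1cncnc1`, which has not yet been measured. The structural change is pyrimidin-5-yl in place of (2-(methoxycarbonyl)ethenyl)carbonyl on an amine nitrogen and it puts pyrimidin-5-yl in place of (2-(methoxycarbonyl)ethenyl)carbonyl on an amine nitrogen.

Among the compounds with values here, no step can be sized from compound 3, which has no number. Within the data shown here, the only reference is compound 1 at 20100 nM and, in this assay, no shift from that level beyond the usual scatter is expected, in either direction. A single reference value leaves this expectation loose, so the range is kept wide. The estimate for compound 4 is 15000 nM with an expected range from 3000 nM to 50000 nM in this read-out.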

Compound 4, half-maximal inhibitory concentration: > 30000 nM
Compound 4: a limit, no number (the forecaster's own chance of this, stated with the estimate: 20%); at least 2.0-fold (0.30 log units) between middle value and limit.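

Compound 4 gives > 30000 nM, which is a limit of the assay and not a number. Neither compound 3 nor compound 4 offers a single number here, so no step can be read between them. The compounds shown leave open which group on the shared core, if any, brings antiproliferative activity appreciably stronger than that of compound 1 at 20100 nM.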